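The source may hold more compounds than are shown below. What is called first, only, known or untested is meant among the compounds shown, and "the series" means these compounds.

Series notes, urotensin receptor binding. Compound 1 `CC(C)C[C@H](NC(=O)c1ccc(Cl)c(Cl)c1)C(=O)N[C@H]1CCN(Cc2ccc(OCCCN(C)C)cc2)C1` gives 126 nM in an assay on HEK293 cells for binding affinity to Urotensin-2 receptor (Homo sapiens), read by radioligand binding; a lower number here means a stronger inhibitor, a higher number a weaker inhibitor. Compound 2 `CC(C)C[C@H](NC(=O)c1ccc(Br)cc1)C(=O)N[C@H]1CCN(Cc2ccc(OCCCN(C)C)cc2)C1` gives 200 nM in this assay. Within the data shown here, the only measured step, a 1.6-fold higher number from compound 1 to compound 2 (0.20 log units; within the scatter), exchanges the aryl group on the carbonyl carbon, and its size lies within the scatter, so the two compounds stand on the same footing; compound 2 has no other neighbour to compare against.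

Compound 3 `CC(C)C[C@H](NC(=O)c1cccs1)C(=O)N[C@H]1CCN(Cc2ccc(OCCCN(C)C)cc2)C1` differs from compound 2 by thiophen-2-yl in place of 4-bromophenyl on a carbonyl carbon. Among the measured compounds shown here, the one step that bears on this change, a 1.6-fold higher number from compound 1 to compound 2 (0.20 log units; within the scatter), also altered the group on the carbonyl carbon and stayed within the scatter. With no further examples, the expectation for compound 3 in this assay is a step of about a 1.4-fold higher number from compound 2 to compound 3 (0.15 log units; within the scatter), which may or may not exceed the scatter. Compound 3 is therefore estimated at 280 nM, with a range from 110 nM to 700 nM.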

Compound 3, inhibition constant: 398 nM
Compound 3: the middle estimate sits 1.4-fold (0.15 log units) below what was measured, and the stated range covers the measured number.
By their numbers in this assay, from the lowest: compounds 1, 2 and 3 (each within the scatter of the next, the first and the last beyond it).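

With thiophen-2-yl, a five-membered aromatic ring with 1 hetero atom, now on the carbonyl carbon, this assay shows a 2.0-fold higher number from compound 2 to compound 3 (0.30 log units; within the scatter), so this exchange for 4-bromophenyl cannot be told apart from repeat measurement. Among these compounds, the exchange for 3,4-dichlorophenyl at the same place gives a 3.2-fold higher number from compound 1 to compound 3 (0.50 log units; beyond the scatter), the first step beyond the scatter, which shows that the number responds to the group at this position, though only modestly so far. Nothing measured here accounts for either step.

As far as these compounds go, whether a saturated ring such as cyclohexyl, or a pyridin-3-yl ring, would be tolerated on this carbonyl carbon remains open. From the compounds shown here alone, it is also open whether a chlorine on the thiophene ring would bring the number back towards that of compound 1.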